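This account rests on a few compounds, and the source may have more. Where it says the series, first, only, none or still open, it means among the compounds named here.

Working notes on the series. Compound 1, `COc1cc(OC)c2c(=O)cc(-c3ccc(OCCF)cc3)oc2c1`, is the one entry in a functional assay (Homo sapiens) for antiproliferative activity, read by resazurin assay, with a stated time of 48 h, tested at 5 uM (a higher number here means a stronger effect of the compound at the concentration tested, a lower number a weaker effect), without a number: compound 1 is reported as "not active" (no number reported). Compound 2, `COc1cc(OC)c2c(=O)cc(-c3ccc(OCCCN(C)C)cc3)oc2c1`, carries the only number shown: in this assay compound 2 gives 36%, so there is no other measured compound to rank it against. Compound 3, `COc1cc(OC)c2c(=O)cc(-c3ccc(OCC(O)CN(C)C)cc3)oc2c1`, has not been measured. It differs from compound 2 by hydroxy in place of hydrogen on a saturated chain carbon bound to two saturated chain carbons. Within the data shown here, no pair of measured compounds differs in one place, so nothing indicates how a change of this kind shifts the read-out. The step from compound 2 to compound 3 is expected to stay within the usual scatter, a number 2 percentage points lower from compound 2 to compound 3 (within the scatter). Compound 3 is therefore estimated at 34%, between 14% and 54%.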

Compound 3, a percentage reported as inhibition, at one concentration (the size of the read-out at that concentration, not a potency): 42%
For compound 3 the middle estimate is 8 percentage points below the measured one; the measured number falls inside the stated range.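

Among these compounds, the change of hydrogen to hydroxy on a saturated chain carbon bound to two saturated chain carbons reads as a number 6 percentage points higher from compound 2 to compound 3 (within the scatter) in this assay, the first step that differs in one place. The 3-(dimethylamino)propoxy chain therefore accepts this hydroxy with no shift in the read-out beyond the scatter. Nothing available bears on why the read-out behaves this way at this position. Still open, from the compounds shown here alone, is whether a methoxy on the same chain carbon, or a pyrrolidine or morpholine in place of the dimethylamino group, would read the same way.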